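Aryloxyacetamides: pyrazin-2-yl for pyridin-2-yl on the amide nitrogen

This account rests on a few compounds, and the source may have more. Where it says the series, first, only, none or still open, it means among the compounds named here.

Working notes on the series. Compound 2 `Cc1ccc(OCC(=O)N(Cc2cccs2)c2ccccn2)cc1` gives 200 nM in an assay on HEK293 cells for agonist activity at transient receptor potential cation channel subfamily M member 8 (Homo sapiens), read by fluorescence and calcium flux, with a stated time of 15 min (a higher number here means that more compound is needed for the effect, a lower number that less compound is needed), and carries the highest number of the three measured compounds. Compound 1 `CCc1ccc(OCC(=O)N(CC)Cc2cccs2)cc1` gives 67 nM in this assay, a lower number than that of compound 2, beyond the scatter. Compound 3 `CCN(Cc1cccs1)C(=O)COc1ccc2c(c1)CCC2` gives 0.8 nM in this assay, the lowest number of the three, far below the other two. For the measured compounds named here, no pair among the measured compounds differs in a single place, so no isolated step can be read from them, and the structures of compound 1 and compound 3 differ from compound 2 at more than one position.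

Compound 4 `Cc1ccc(OCC(=O)N(Cc2cccs2)c2cnccn2)cc1` is the next compound and differs from compound 2 in one place: pyrazin-2-yl in place of pyridin-2-yl on an amide-type nitrogen. Nothing measured here addresses a pyrazin-2-yl on this amide nitrogen, and the two six-membered rings match in size. A modest step is expected, if any, with a higher number more likely than a lower one, since compound 2 already holds the highest number with 200 nM. The estimated step of a 1.5-fold higher number from compound 2 to compound 4 (0.18 log units; within the scatter) stays near the scatter. Compound 4 is expected at 300 nM, in a range of 100 nM to 1000 nM.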

Compound 4, half-maximal effective concentration: 1240 nM
For compound 4 the middle estimate is 4.1-fold (0.62 log units) below the measured one, and the stated range ends below it.
By their numbers in this assay, from the lowest: compound 3; then compound 1; then compound 2; then compound 4.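

For the compounds shown here, this is the first isolated step: in this assay, pyrazin-2-yl in place of pyridin-2-yl on the amide-type nitrogen gives a 6.2-fold higher number from compound 2 to compound 4 (0.79 log units; beyond the scatter). The position therefore responds to a change that keeps the ring size and the heavy-atom count, exchanging only a ring carbon for a nitrogen and adding a hydrogen-bond acceptor to the count, so the identity of the ring atoms matters here and not the ring size alone. Nothing available bears on the reason for this step.

As far as these compounds go, this single step cannot separate the effect of the added ring nitrogen from that of its location in the ring, so it remains open whether a pyrimidin-2-yl, a pyridin-3-yl or a plain phenyl on this nitrogen would read close to compound 2 or close to compound 4. Going by these compounds alone, it is equally open whether the same exchange would move the number as far on the other aryloxy groups, such as the one carried by compound 3.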